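The source may report more compounds than this note shows. Statements on the series, on what has been measured and on what is new or still open speak of the compounds shown alone.

Among the compounds with values here, in a functional assay on Bel-7402 cells (Homo sapiens) for inhibition, read by MTT assay, with a stated time of 24 h, tested at 100 ug/mL (a lower number here means less inhibition of growth, a higher number more inhibition of growth at the concentration tested), only two compounds have numbers so far. Compound 1 `O=C(CCCCC1CCSS1)Nc1cccc(C(F)(F)F)c1` gives 61.9% and compound 2 `O=C(CCCCC(S)CCS)Nc1ccc(Cl)cc1` gives 25.5% as the lower of the pair, a gap beyond the usual scatter of repeated measurements. These two compounds differ in more than one place, so the gap cannot be tied to any single feature. Compound 3 `O=C(CCCCC(S)CCS)Nc1ccc([N+](=O)[O-])cc1` keeps all of compound 2 except one group, with nitro in place of chloro on an aromatic carbon, para to a large group nitro in place of chloro on an aromatic carbon in the new structure. Within the data shown here, no measured pair shows what this swap does in this assay on its own, so the expectation starts from compound 2 at 25.5% and allows a small rise, probably none beyond the scatter. The estimated change is a number 4.5 percentage points higher from compound 2 to compound 3 (within the scatter) in this read-out. Compound 3 is expected to give 30% with a likely range from 15% to 48% when it is measured.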

Compound 3, percent growth inhibition at one concentration: 33.4%
Estimate against measurement, compound 3: 3.4 percentage points below; the range from low to high includes it.
By their numbers in this assay, from the lowest: compounds 2 and 3 (each within the scatter of the next); then compound 1.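

In this assay, nitro in place of chloro on an aromatic carbon, para to a large group, gives a number 7.9 percentage points higher from compound 2 to compound 3 (within the scatter), so the two compounds cannot be told apart. Within the data shown here, this is the first comparison here that changes a single place, and it shows that the reading at this position holds within the scatter even though nitro brings more heavy atoms and more hydrogen-bond acceptors than chloro. Nothing measured here offers a reason for this result.

On these data alone, whether an amine or a carboxylic acid at the same place would also leave the reading within the scatter remains open. As far as these compounds go, compound 1 differs from compound 2 in more than one place, so which of its features goes with its higher reading also remains open.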